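Compound 2 to compound 4: a new group on the carbonyl

This account rests on a few compounds, and the source may have more. Where it says the series, first, only, none or still open, it means among the compounds named here.

In a physicochemical assay for solubility, read by mass spectrometry, in phosphate buffer, with a stated time of 24 h, at pH 7.4 (on this read-out lower numbers stand for lower solubility and higher numbers for higher solubility), compound 1 `Cc1ccoc1C(=O)N1CCC(NC(=O)Nc2ccc(C(F)(F)F)cc2)CC1` gives 0.8 ug/mL and compound 2 `Cc1ccoc1C(=O)N1CCC(NC(=O)Nc2ccc(OC(F)(F)F)cc2)CC1` gives 0.92 ug/mL. Compound 3 `CC(C)C(=O)N1CCC(NC(=O)Nc2ccc(C(F)(F)F)c(F)c2)CC1` gives 5.9 ug/mL, the highest of the three numbers and beyond the scatter from compound 2. Compound 2 therefore sits in the low pair with compound 1.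

Compound 4 `O=C(Nc1ccc(OC(F)(F)F)cc1)NC1CCN(C(=O)c2cc[nH]c2)CC1` has not yet been measured. It carries 1H-pyrrol-3-yl in place of 3-methylfuran-2-yl on a carbonyl carbon.

Going by the values given here, the only measured single change is a 1.2-fold higher number from compound 1 to compound 2 (0.06 log units; within the scatter). That change lies on an aromatic carbon and not on the carbonyl carbon, so it offers no direct guide to this step. Compound 3, at 5.9 ug/mL, also has a different group on a carbonyl carbon, but it differs from compound 2 elsewhere too. Among the compounds with values here, it shows only that higher numbers occur, and no measured pair isolates the present change.

A small upward move in this assay is expected, with low confidence in its direction and size, and the estimated step is a 2.0-fold higher number from compound 2 to compound 4 (0.29 log units; within the scatter). For compound 4 the estimated value is 1.8 ug/mL, with an expected range of 0.5 ug/mL to 6 ug/mL.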

Compound 4, solubility: 43 ug/mL
Estimate against measurement, compound 4: 24-fold (1.38 log units) below; the measured number lies above the stated range.
By their numbers in this assay, from the lowest: compounds 1 and 2 (each within the scatter of the next); then compound 3; then compound 4.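

In this assay, 1H-pyrrol-3-yl in place of 3-methylfuran-2-yl on a carbonyl carbon gives a 47-fold higher number from compound 2 to compound 4 (1.67 log units; beyond the scatter), so the group at this carbonyl can move the read-out far beyond the scatter while the rest of the structure stays the same. Going by these compounds alone, the only earlier single change, a 1.2-fold higher number from compound 1 to compound 2 (0.06 log units; within the scatter), lay on an aromatic carbon and gave no view of this position, which now has a large step of its own. The exchange alters several counted features at once: a ring oxygen gives way to a ring nitrogen, the methyl group goes, a hydrogen-bond donor enters and a hydrogen-bond acceptor leaves, and nothing measured here explains the size of the step.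

The compounds shown do not separate these features, and a furan ring without the methyl group or a pyrrole ring carrying a methyl group on its nitrogen would bear directly on that question. Also open, as far as these compounds go, is whether a step of this size would recur with trifluoromethyl in place of trifluoromethoxy on the aromatic carbon.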